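Replacing one dimethoxyphenyl by a bromophenyl in the series

The source may report more compounds than this note shows. Statements on the series, on what has been measured and on what is new or still open speak of the compounds shown alone.

Compound 1 `COc1cc(OC)c(OC)cc1/C=C/COC(=O)/C=C/c1ccc(OC)c(OC)c1` gives 100% in a functional assay on the whole organism (strain Kunming) with Mus musculus as the target, with a stated time of 0.5 h, at a dose of 300 mg/kg by the intraperitoneal route; on this read-out higher numbers stand for a weaker effect at the one dose given and lower numbers for a stronger effect. Compound 2 `COc1cc(OC)c(OC)cc1/C=C/COC(=O)/C=C/c1c(OC)ccc(OC)c1OC` gives 100% and compound 3 `COc1cc(OC)c(OC)cc1/C=C/COC(=O)/C=C/c1cc(OC)c(OC)c(OC)c1` gives 100% in this assay, so compound 1 stands level with both at the digits shown. Among the measured compounds shown here, the only single-point step measured, no change at the digits printed from compound 1 to compound 3 (within the scatter), puts a methoxy in place of hydrogen on an aromatic carbon and leaves the read-out unchanged within the scatter. Compound 4 `COc1cc(OC)c(OC)cc1/C=C/COC(=O)/C=C/c1cccc(Br)c1` differs from compound 1 by 3-bromophenyl in place of 3,4-dimethoxyphenyl on a double-bonded chain carbon bound to a double-bonded chain carbon. For the measured compounds named here, no measured step removes methoxy groups or brings in bromine, so the series bears on this change only indirectly: all three measured compounds sit at one value and the one step among them is flat. A small step at most is therefore expected, no change at the digits printed from compound 1 to compound 4 (within the scatter). Compound 4 is estimated at 100%, within a range of 75% to 100%.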

Compound 4, a percentage reported as activity, at one dose (the size of the read-out at that dose, not a potency): 100%
For compound 4 middle estimate and measured number coincide at the digits printed, and the stated range covers the measured number.
By their numbers in this assay, from the lowest: compounds 1, 2, 3 and 4 (each within the scatter of the next).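

In this assay, the step to the bromo analogue reads no change at the digits printed from compound 1 to compound 4 (within the scatter): the flat picture at this position now extends beyond adding a methoxy to a change that removes both methoxy groups and brings in bromine. At this one dose, the 3,4-dimethoxyphenyl can therefore give way to 3-bromophenyl with no visible effect on the read-out. Nothing available explains this flat result.

Going by these compounds, it remains open whether an amine or a carboxylic acid on this aromatic ring, or a longer chain in its place, would move the read-out away from the level shared by compounds 1, 2, 3 and 4. With all four at one level, the compounds shown do not reveal which features at this position, if any, govern the effect.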